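A few compounds are considered here, and "the series" means these few. Any claim that something is new, unique, unknown or untested is made for them only; others in the source may bear on it.

Compound 3, `C=CCn1c(=O)/c(=C\c2cc(Br)ccc2F)[nH]c(=O)/c1=C\c1ccccc1OC`, carries a 5-bromo-2-fluorophenyl on a double-bonded chain carbon bound to an aromatic carbon of the shared core. In a functional assay on MOLT-4 cells (Homo sapiens) for cytotoxicity, read by CCK-8 assay, with a stated time of 72 h (on this read-out higher numbers stand for weaker inhibition and lower numbers for stronger inhibition), compound 3 gives 12900 nM, the highest number among the compounds with a reported value. Its nearest neighbour is compound 1, `C=CCn1c(=O)/c(=C\c2cccc(Cl)c2)[nH]c(=O)/c1=C\c1ccccc1OC`, which gives 4900 nM; the step is a 2.6-fold higher number from compound 1 to compound 3 (0.42 log units; beyond the scatter). Compound 2, `C=CCn1c(=O)/c(=C\c2ccc(Cl)c(Cl)c2)[nH]c(=O)/c1=C\c1ccccc1OC`, was reported as "not active" (no number reported), without a number.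

Compound 4, `C=CCn1c(=O)/c(=C\c2ccc(F)c(Br)c2)[nH]c(=O)/c1=C\c1ccccc1OC`, differs from compound 3 only in the arrangement of the same atoms: 3-bromo-4-fluorophenyl in place of 5-bromo-2-fluorophenyl on a double-bonded chain carbon bound to an aromatic carbon. Among the measured compounds shown here, no measured step changes the placement of two halogens on this ring in the same way, so the only guide is that the two reported numbers lie within a modest step of each other, while the compound with two halogens side by side gave no number at all. The expectation for compound 4 is therefore a step of roughly a 1.1-fold higher number from compound 3 to compound 4 (0.04 log units; within the scatter), a weaker inhibition than compound 3 at about the same level, with a real chance that no number is reported. The estimate for compound 4 in this assay is 14000 nM, within a range from 5000 nM to 40000 nM.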

Compound 4, half-maximal inhibitory concentration: "not active" (no number reported)
Nothing numeric was reported for compound 4, so the estimate cannot be set against anything.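

In this assay, among the compounds shown here, compound 4 is reported as "not active" (no number reported), so no step from compound 3 to compound 4 can be read. What the compounds shown leave open is how far rearranging the bromine and fluorine on this ring shifts the reading. Nothing given here offers an explanation for this result.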